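Ring size of the chain amine in compound 4

The source may report more compounds than this note shows. Statements on the series, on what has been measured and on what is new or still open speak of the compounds shown alone.

Values measured in a functional assay on HT-29 cells (Homo sapiens) for cytotoxicity, read by MTT assay, with a stated time of 72 h; a lower number here means a stronger inhibitor, a higher number a weaker inhibitor:
compound 1 `COc1cc2c(Oc3ccc(NC(=O)c4nn(-c5ccccc5)c(=O)c5ccccc45)cc3F)ccnc2cc1OCCCN1CCCC1`: 980 nM
compound 2 `COc1cc2c(Oc3ccc(NC(=O)c4nn(-c5cccc(F)c5)c(=O)c5ccccc45)cc3F)ccnc2cc1OCCCN1CCCC1`: 460 nM
compound 3 `COc1cc2c(Oc3ccc(NC(=O)c4nn(-c5ccccc5Br)c(=O)c5ccccc45)cc3F)ccnc2cc1OCCCN1CCCC1`: 850 nM

Compound 1 has the highest number of the three. Its steps to the others are a 2.1-fold lower number from compound 1 to compound 2 (0.33 log units; beyond the scatter) and a 1.2-fold lower number from compound 1 to compound 3 (0.06 log units; within the scatter); both alter the phenyl on the aromatic nitrogen. Compound 4 `COc1cc2c(Oc3ccc(NC(=O)c4nn(-c5ccccc5)c(=O)c5ccccc45)cc3F)ccnc2cc1OCCCN1CCCCC1` is changed elsewhere: piperidin-1-yl in place of pyrrolidin-1-yl on a saturated chain carbon, three bonds along the chain from an oxygen on an aromatic ring. Within the data shown here, no measured step touches this chain amine, so the record gives nothing that bears on the change. Without such a step, the expectation for compound 4 in this assay is a step of no change at the digits printed from compound 1 to compound 4 (within the scatter), that is nothing beyond the scatter. Compound 4 is accordingly estimated at 980 nM, with a range from 400 nM to 2400 nM.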

Compound 4, half-maximal inhibitory concentration: 1310 nM
The estimate for compound 4 lay 1.3-fold (0.13 log units) below the measured number; the range from low to high includes it.
By their numbers in this assay, from the lowest: compounds 2, 3, 1 and 4 (each within the scatter of the next, the first and the last beyond it).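

Among these compounds, this is the first step at the chain amine rather than at the phenyl on the aromatic nitrogen. In this assay it gives a 1.3-fold higher number from compound 1 to compound 4 (0.13 log units; within the scatter) and so a six-membered ring in place of a five-membered one at the end of the 3-(pyrrolidin-1-yl)propyl chain makes no difference beyond the scatter. Nothing available explains this result.

From the compounds shown here alone, it remains open whether a morpholine, an open-chain dimethylamino group or a longer chain would behave the same way here. Going by these compounds, it is also open whether piperidin-1-yl would give the same result alongside the 3-fluorophenyl of compound 2.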